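This account rests on a few compounds, and the source may have more. Where it says the series, first, only, none or still open, it means among the compounds named here.

Measured compounds:
compound 1, `C[C@@H](O)[C@H](NC(=O)CN(c1nc(Cl)nc2[nH]cnc12)C1CC1)C(=O)OCc1ccccc1`, 12.8%
compound 2, `C[C@@H](O)[C@H](NC(=O)CN(c1nc(Cl)nc2[nH]cnc12)C1CC1)C(=O)O`, 24%

In a functional assay on the whole organism (Tail, strain ICR) with Mus musculus as the target, in the tail flick test, with a stated time of 150 min, at a dose of 25 umol/kg by the oral route (a higher number here means a stronger effect of the compound at the dose given, a lower number a weaker effect), compound 1 stands lowest of the two; its nearest neighbour is compound 2, reached by a number 11.2 percentage points higher from compound 1 to compound 2 (beyond the scatter), a change of hydrogen in place of benzyl on an oxygen next to a carbonyl group. Compound 3, `CC(C)C[C@H](NC(=O)CN(c1nc(Cl)nc2[nH]cnc12)C1CC1)C(=O)OCc1ccccc1`, differs from compound 1 by isobutyl in place of 1-hydroxyethyl on a saturated chain carbon bound to an amide-type nitrogen and a carbonyl carbon. For the measured compounds named here, no measured step touches that place, so the one known step offers no guide, and the expected change is none beyond the scatter, a number 1.2 percentage points higher from compound 1 to compound 3 (within the scatter). Compound 3 is therefore estimated at 14%, within a range of 2% to 32%.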

Compound 3, a percentage reported as activity, at one dose (the size of the read-out at that dose, not a potency): 5.26%
Compound 3: middle estimate off by 8.7 percentage points, on the high side; the measured number falls inside the stated range.
By their numbers in this assay, from the lowest: compounds 3 and 1 (each within the scatter of the next); then compound 2.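

In this assay, for the compounds shown here, the only measured change on the saturated chain carbon bound to an amide-type nitrogen and a carbonyl carbon gives a number 7.5 percentage points lower from compound 1 to compound 3 (within the scatter) and shows that, with the benzyl ester kept, isobutyl can replace 1-hydroxyethyl without a shift beyond the scatter. At this place, the read-out does not separate these two groups. Nothing at hand offers an explanation for this result. Still open, as far as these compounds go, is whether the same replacement holds with hydrogen in place of benzyl, as in compound 2, and whether an amine or a longer chain at this place would move the number beyond the scatter.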